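A Methyl Added Two Bonds From the Amide Nitrogen

This account rests on a few compounds, and the source may have more. Where it says the series, first, only, none or still open, it means among the compounds named here.

Of the compounds shown here, three have been measured in a functional assay on CHO cells for positive allosteric modulation of muscarinic acetylcholine receptor M5 (Homo sapiens), read by calcium flux; a higher number here means a larger maximal response, a lower number a smaller maximal response. Compound 1, `CCN(Cc1ccccc1)C(=O)C1CCN(S(=O)(=O)c2ccc(OC)cc2)CC1`, gives 84%. Compound 2, `CCN(C(=O)C1CCN(S(=O)(=O)c2ccc(OC)cc2)CC1)[C@H](C)c1ccccc1`, carries methyl in place of hydrogen on a saturated chain carbon bound to an amide-type nitrogen and an aromatic carbon, and in this assay compound 2 gives 90%, so that the change made a number 6 percentage points higher from compound 1 to compound 2 (within the scatter). Compound 3, `CCN(Cc1ccccc1C(F)(F)F)C(=O)C1CCN(S(=O)(=O)c2ccc3[nH]ncc3c2)CC1`, differs from compound 1 in more than one place, and the difference between the two cores is not broken down here. In this assay compound 3 gives 96%; the difference between compound 3 and compound 2 lies within the scatter, while the gap between compound 3 and compound 1 lies beyond it.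

Compound 4, `CCCN(Cc1ccccc1C(F)(F)F)C(=O)C1CCN(S(=O)(=O)c2ccc3[nH]ncc3c2)CC1`, has not yet been measured. It carries methyl in place of hydrogen on a saturated chain carbon, two bonds along the chain from an amide-type nitrogen. Among the compounds with values here, this is the same kind of change as the one made from compound 1 to compound 2, but not the same: there the added carbon sits on a saturated chain carbon bound to an amide-type nitrogen and an aromatic carbon, whereas here it sits on a saturated chain carbon two bonds along the chain from an amide-type nitrogen. A step of similar, small size is expected for compound 4 because a number 6 percentage points higher from compound 1 to compound 2 (within the scatter) stayed within the scatter, and the expectation is a number 1 percentage points lower from compound 3 to compound 4 (within the scatter). Compound 4 is therefore estimated to reach 95% in this assay, with the expected range running from 80% to 108%.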

Compound 4, largest response reached (reported as percent of maximum), in percent of the reference or control that the assay uses: 94%
Compound 4: the middle estimate sits 1 percentage points above what was measured; measured number inside the range.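

In this assay, adding one methyl that turns ethyl into propyl, on a saturated chain carbon two bonds along the chain from an amide-type nitrogen, gives a number 2 percentage points lower from compound 3 to compound 4 (within the scatter), a step too small to separate the two compounds. Set beside the earlier methyl step, made on a different kind of chain carbon and on a different core, this step gives no sign that the core changes the outcome of adding a methyl: the same change on two cores in this assay, a number 6 percentage points higher (within the scatter) from compound 1 to compound 2 and a number 2 percentage points lower (within the scatter) from compound 3 to compound 4, 8 percentage points apart, within the scatter of two such steps

Within the data shown here, this agreement rests on only two pairs, and since neither step rises above the noise of repeated measurements, it shows that both cores keep a similar maximal response after a methyl is added, not that the methyl has a real effect of a set size or direction that carries from one core to another.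

The compounds shown leave open what a longer chain, such as butyl, or a chain ending in an amine or a carboxylic acid, would do at this place. They also leave open whether a methyl step would stay this small on any further core in the series.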